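Working notes: compound 2 to compound 3

This account rests on a few compounds, and the source may have more. Where it says the series, first, only, none or still open, it means among the compounds named here.

Compound 1 `Cc1oc(-c2ccc(Cl)cc2)nc1CN1CCC(C(=O)NCCCN2C[C@H](C)C[C@H](C)C2)CC1` gives > 635 10^-6 cm/s (a limit)
Compound 2 `Cc1ccccc1-c1nc(CN2CCC(C(=O)NCCCN3CCC(C)CC3)CC2)c(C)o1` gives 425 10^-6 cm/s (a number)

Among the compounds with values here, in a physicochemical assay for permeability, using PAMPA (on this read-out lower numbers stand for lower permeability and higher numbers for higher permeability), compound 2 at 425 10^-6 cm/s holds the only true number so far. Compound 1 at > 635 10^-6 cm/s is a limit of the assay and not a number. Compound 3 `Cc1ccccc1-c1nc(CN2CCC(C(=O)NCCN3C[C@H](C)C[C@H](C)C3)CC2)c(C)o1` is still unmeasured. The step 3,5-dimethylpiperidin-1-yl in place of (4-methylpiperidin-1-yl)methyl on a saturated chain carbon, two bonds along the chain from an amide-type nitrogen keeps the same atoms but joins them differently. Within the data shown here, no measured step covers this change. In this assay no shift beyond the usual scatter is expected. The estimated 1.1-fold higher number from compound 2 to compound 3 (0.02 log units; within the scatter) stays within that scatter. For compound 3 the expected value is 450 10^-6 cm/s with an estimated range of 230 10^-6 cm/s to 800 10^-6 cm/s on this read-out.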

Compound 3, apparent permeability: 712 10^-6 cm/s
The estimate for compound 3 lay 1.6-fold (0.20 log units) below the measured number; the measured number falls inside the stated range.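

In this assay, within the data shown here, 3,5-dimethylpiperidin-1-yl in place of (4-methylpiperidin-1-yl)methyl on a saturated chain carbon gives a 1.7-fold higher number from compound 2 to compound 3 (0.22 log units; within the scatter), the first step that can be read. The same atoms, joined differently at this place, thus give no shift beyond the scatter. One value in the series is a limit of the assay and not a number: the limit of > 635 10^-6 cm/s in this assay, at which 1 of the 3 values shown sits.

The step joins 3-(4-methylpiperidin-1-yl)propyl to 2-(3,5-dimethylpiperidin-1-yl)ethyl, so chain and ring methyl groups remain unseparated. Open, on these data alone, is how a primary amine or carboxylic acid at this place would read in this assay.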